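From 4-chlorophenyl to 2-fluorophenyl on a shared core

The compounds below may be only part of what the source reports. "The series", "measured", "known", "first", "only" and "open" are said of these compounds alone.

- Compound 1 `CC(C)(C)n1ncc(OCc2nnc(-c3ccc(Cl)cc3)s2)c(Cl)c1=O` (106 ug/mL)
- Compound 2 `CC(C)(C)n1ncc(SCc2nnc(-c3cccc(F)c3)o2)c(Cl)c1=O` (243 ug/mL)

Both values come from a functional assay on the whole organism for inhibition, with Mythimna separata as the target, with a stated time of 5 days (a lower number here means that less compound is needed, a higher number that more compound is needed for the effect), and compound 1 holds the lower number of the two, with compound 2 higher by a gap beyond the usual scatter. Going by the values given here, the two compounds differ in more than one place, and no measured pair shows what a single change does.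

The next compound, compound 3 `CC(C)(C)n1ncc(OCc2nnc(-c3ccccc3F)s2)c(Cl)c1=O`, keeps the core of compound 1 but carries 2-fluorophenyl in place of 4-chlorophenyl on an aromatic carbon. That carbon belongs to a five-membered aromatic ring with 2 nitrogen and 1 sulfur.

Among the compounds with values here, with only two measurements, any expectation here is a loose one. Within the data shown here, compound 1 (106 ug/mL) is the lowest number known so far, and a swap starting from the lower of two values is expected to move up more readily than down. The expected step of a 1.6-fold higher number from compound 1 to compound 3 (0.21 log units; within the scatter) in this assay is therefore small, toward a higher number, and not clearly beyond the scatter. For compound 3 the expected value is 170 ug/mL within an estimated range (70 ug/mL to 400 ug/mL).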

Compound 3, half-maximal effective concentration: 121 ug/mL
The estimate for compound 3 lay 1.4-fold (0.15 log units) above the measured number; the range from low to high includes it.
By their numbers in this assay, from the lowest: compounds 1, 3 and 2 (each within the scatter of the next, the first and the last beyond it).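

In this assay, going by these compounds alone, putting 2-fluorophenyl in place of 4-chlorophenyl on an aromatic carbon of the five-membered aromatic ring with 2 nitrogen and 1 sulfur gives a 1.1-fold higher number from compound 1 to compound 3 (0.06 log units; within the scatter), the first comparison here in which only one place differs. The result shows that, in this whole-organism test, this position accepts either of these two halogen-bearing phenyl groups with no difference that can be told apart from ordinary repeat-to-repeat variation, so the two compounds stand level on the shared core. No separate measurement is available that would explain why these two groups read alike.

The swap alters both the halogen and where it sits on the phenyl ring, so a single result cannot separate these two features, and only a matched pair such as 2-chlorophenyl against 4-chlorophenyl, or 4-fluorophenyl against 2-fluorophenyl, could do so. From the compounds shown here alone, it also remains open how this position responds to groups of another kind, such as plain phenyl without a halogen, 4-methoxyphenyl, or a ring carrying an amine.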